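Adding a Methoxy Group to a Bromo Benzanilide

The source may report more compounds than this note shows. Statements on the series, on what has been measured and on what is new or still open speak of the compounds shown alone.

In an assay for inhibition of HSP60/HSP10 (Homo sapiens), with a stated time of 60 min (a lower number here means a stronger inhibitor, a higher number a weaker inhibitor), compound 3 `O=C(Nc1ccccc1)c1cccc(Br)c1` gives > 100000 nM, which is a limit of the assay rather than a number. Compound 2 `O=C(Nc1ccccc1)c1cc(Br)ccc1O` gives > 100000 nM in this assay, again a limit. Compound 1 `COc1c(Br)cc(Br)cc1C(=O)Nc1ccccc1` gives > 100000 nM in this assay as well, also a limit. All three values sit at the limit of > 100000 nM in this assay, at which 3 of the 3 values shown sit, so compound 3 cannot be placed above or below either of the other two; it stands only at that limit. Among the measured compounds shown here, the one single-point step among the measured compounds, a step that the two limits leave unreadable from compound 2 to compound 3, has no readable size, as both of its ends are limits.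

Compound 4 `COc1ccc(Br)cc1C(=O)Nc1ccccc1` has not yet been measured. It differs from compound 3 by methoxy in place of hydrogen on an aromatic carbon. For the measured compounds named here, no measured step with a readable size bears on this change. Compound 1, which also carries a methoxy group on its core, is itself reported only as a limit in this assay. The expected step that the limit leaves unreadable from compound 3 to compound 4 is therefore none beyond the scatter, in the sense that compound 4 is expected to remain at the limit. For compound 4 the estimate is 150000 nM, with a range from 50000 nM to 500000 nM, most likely reported again as a limit and not as a number.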

Compound 4, half-maximal inhibitory concentration: > 100000 nM
Compound 4 ended at the assay's limit; the forecaster's own chance of this, stated with the estimate: 85%; the middle value does not contradict the limit.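

No step can be read from compound 3, compound 2 or compound 1 to compound 4, because both ends of each step are limits and not numbers: the limit of > 100000 nM in this assay, at which 4 of the 4 values shown sit. The compounds shown leave open whether the methoxy, hydroxy or bromo groups on the shared core change inhibition at all in this assay.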